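The source may report more compounds than this note shows. Statements on the series, on what has been measured and on what is new or still open speak of the compounds shown alone.

Measured so far in a functional assay on HeLa cells (Homo sapiens) for antiproliferative activity, read by MTT assay, with a stated time of 48 h; on this read-out higher numbers stand for weaker inhibition and lower numbers for stronger inhibition:
- compound 1 `COc1ccc(C(=O)c2ccc(OC)c3c2OC(C)(C)C=C3)c(NC(=O)CN)c1`: 410 nM
- compound 2 `CCNCC(=O)Nc1cc(OC)ccc1C(=O)c1ccc(OC)c2c1C=CC(C)(C)O2`: 4270 nM

Compound 1 holds the lowest number of the pair, and the gap up to compound 2 lies beyond the scatter. The next compound to be read is compound 3 `COc1ccc(C(=O)c2ccc(OC)c3c2OC(C)(C)C=C3)c(NC(=O)CN(C)C)c1`. Against compound 1 it carries dimethylamino in place of amino on a saturated chain carbon bound to a carbonyl carbon, with dimethylamino in place of amino on a saturated chain carbon bound to a carbonyl carbon. Within the data shown here, no measured pair shows this change, so the expectation rests on little: only the two values, with compound 1 at 410 nM and compound 2 at 4270 nM. In this assay a moderate rise, just beyond the scatter, is expected, and the estimated step is a 3.2-fold higher number from compound 1 to compound 3 (0.50 log units; beyond the scatter). For compound 3 the estimated value is 1300 nM, with an expected range of 350 nM to 5000 nM.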

Compound 3, half-maximal inhibitory concentration: 1050 nM
The estimate for compound 3 lay 1.2-fold (0.09 log units) above the measured number, and the stated range covers the measured number.
By their numbers in this assay, from the lowest: compound 1; then compound 3; then compound 2.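

In this assay, among these compounds, dimethylamino in place of amino on a saturated chain carbon bound to a carbonyl carbon gives a 2.6-fold higher number from compound 1 to compound 3 (0.41 log units; beyond the scatter), the first step read at a single place. Substitution at this nitrogen lowers potency modestly without abolishing it, as compound 3 still reads 1050 nM in this assay. The change adds two carbons and removes the hydrogen-bond donor counted on amino, and no measurement at hand bears on why the number rises.

With a single replacement shown at this place on the core of compound 1, the separate contributions of the added carbons and the lost donor stay open. Also open, from the compounds shown here alone, is how methylamino, a pyrrolidine ring or a longer chain between carbonyl and amine would read on that core.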